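The compounds below may be only part of what the source reports. "The series", "measured", "known", "first", "only" and "open" are said of these compounds alone.

Measured compounds:
- compound 1, `COC(=O)C1=C(c2ccc(Cl)c(Cl)c2)CCC1`, 5500 nM in a functional assay on COS-1 cells for inhibition of sodium-dependent dopamine transporter (Homo sapiens); a higher number here means a weaker inhibitor, a lower number a stronger inhibitor
- compound 2, `COC(=O)C1=C(c2ccc(C(C)(C)C)cc2)CCC1`, "not determined" (no result reported)
- compound 3, `COC(=O)C1=C(c2ccc(OC(F)(F)F)cc2)CCC1`, "not determined" (no result reported)

Only compound 1 carries a number in this assay. For the measured compounds named here, compound 2 and compound 3 are entered without a result, so compound 3 has no place on the scale at all: nothing is known of how it compares with compound 1, and no step from any measured compound to compound 3 can be stated. The shared core of all three is the same; they differ in the substituent on the aromatic ring.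

The next compound, compound 4, `COC(=O)C1=C(c2ccc(C(C)=O)cc2)CCC1`, differs from compound 3 in one place:
acetyl in place of trifluoromethoxy on an aromatic carbon

Going by the values given here, since compound 3 has no number, no step to compound 4 can be computed, and no direction or size of change is set by the data. Only compound 1 gives an anchor for the series in this assay.

Compound 4 is estimated to give about 20000 nM in this assay, with an expected range from 4000 nM to 100000 nM.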

Compound 4, inhibition constant: 49000 nM
Compound 4: middle estimate off by 2.5-fold (0.39 log units), on the low side; the measured number falls inside the stated range.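

For the compounds shown here, compound 3 has no number in this assay, and no step from it to compound 4 can be read. No supporting data bear on the result for compound 4. The compounds shown leave open how acetyl and trifluoromethoxy compare on the aromatic ring in this assay.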